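A few compounds are considered here, and "the series" means these few. Any claim that something is new, unique, unknown or untested is made for them only; others in the source may bear on it.

Measured compounds:
Compound 1, `Fc1cccc(Nc2nc(-c3cccc(F)c3)nc3ccc(F)cc23)c1`: in a functional assay on HT29-AK cells (Homo sapiens) for cytotoxicity, read by MTT assay, with a stated time of 48 h (on this read-out lower numbers stand for stronger inhibition and higher numbers for weaker inhibition), compound 1 gives > 50000 nM, a limit of the assay.
Compound 2, `Fc1cccc(-c2nc(Nc3cccc(Cl)c3)c3cc(F)ccc3n2)c1`: in this assay compound 2 gives > 50000 nM, a limit of the assay.

Compound 2 stands at the limit of > 50000 nM in this assay, at which 2 of the 2 values shown sit. Compound 1 sits there as well. Among the measured compounds shown here, the only measured step, a step that the two limits leave unreadable from compound 1 to compound 2, is not readable in size. Compound 3, `Fc1cccc(-c2nc(Nc3cccc(Br)c3)c3cc(F)ccc3n2)c1`, differs from compound 2 by bromo in place of chloro on an aromatic carbon. For the measured compounds named here, no measured step with a readable size bears on this change; the earlier halogen swap left both compounds at the limit. The step that the limit leaves unreadable from compound 2 to compound 3 is expected to be none beyond the scatter. Compound 3 is estimated at 60000 nM (20000 nM to 200000 nM), and is expected most likely to be reported again only as a limit.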

Compound 3, half-maximal inhibitory concentration: > 50000 nM
Compound 3 was reported as a limit; the forecaster's own chance of this, stated with the estimate: 85%; the middle value is on the limit's open side.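

No step can be read from compound 3 to compound 1 or compound 2, since all three values are limits: the limit of > 50000 nM in this assay, at which 3 of the 3 values shown sit.

The compounds shown leave open whether any halogen swap here changes cytotoxicity in this assay, and how far each compound lies past the limit.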